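The source may report more compounds than this note shows. Statements on the series, on what has been measured and on what is new or still open speak of the compounds shown alone.

Measured in a functional assay for inhibition, with Homo sapiens as the target; on this read-out lower numbers stand for stronger inhibition and higher numbers for weaker inhibition:
compound 1 `CCCc1nc(C)c2c(C)nn(CC)c(=O)n12` — > 48000 nM, a limit of the assay
compound 2 `CCCc1nc(C)c2c(C)nn(CCC)c(=O)n12` — > 48000 nM, a limit of the assay
compound 3 `C=C=Cn1nc(C)c2c(C)nc(CCC)n2c1=O` — > 48000 nM, a limit of the assay

Compound 3 stands where every measured compound of the series stands: at the limit of > 48000 nM in this assay, at which 3 of the 3 values shown sit, with no number behind it. The steps among the measured compounds are accordingly unreadable: a step that the two limits leave unreadable from compound 1 to compound 2, a step that the two limits leave unreadable from compound 1 to compound 3 and a step that the two limits leave unreadable from compound 2 to compound 3. Among the measured compounds shown here, the series so far gives no readable step at all.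

The next compound is compound 4 `CCCc1nc(C)c2c(C)nn(Cc3ccccc3)c(=O)n12`. The change from compound 3 is benzyl in place of propa-1,2-dien-1-yl on an aromatic nitrogen. For the measured compounds named here, no measured step bears on it in a readable way; the three steps between compounds sitting at the limit say nothing about size or direction. What the measured compounds show is only that ethyl, propyl and propa-1,2-dien-1-yl on that nitrogen all leave the compound at the limit. For compound 4 the step of a number no higher from compound 3 to compound 4 (the limit leaves the size open) is therefore expected to be none readable beyond the scatter. Compound 4 is accordingly estimated at 48000 nM, within 15000 nM to 150000 nM, and most likely reported again only as a limit in this assay.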

Compound 4, half-maximal inhibitory concentration: > 48000 nM
Compound 4 was reported as a limit; the forecaster's own chance of this, stated with the estimate: 70%; the middle value sits exactly at the limit.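

In this assay compound 4 gives > 48000 nM, a limit of the assay and not a number. Among the compounds shown here, no new step can therefore be read between compound 4 and compound 1, compound 2 or compound 3. The compounds shown leave open how strongly any of them inhibits, and whether any group on the aromatic nitrogen would give a measurable value: the limit of > 48000 nM in this assay, at which 4 of the 4 values shown sit.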